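Shortening the ether chain on the shared core

The source may hold more compounds than are shown below. What is called first, only, known or untested is meant among the compounds shown, and "the series" means these compounds.

Compound 3 `CC(C)CCOc1ccc2oc(/C=C/[S+](C)[O-])cc(=O)c2c1` stands at 4100 nM in a functional assay on DLD-1 cells (Homo sapiens) for cytotoxicity, with a stated time of 48 h (on this read-out lower numbers stand for stronger inhibition and higher numbers for weaker inhibition), the lowest of the two numbers available in this assay. Compound 1 `CCCOc1ccc2oc(/C=C/[S+](C)[O-])cc(=O)c2c1` gives 6200 nM in this assay, and the pair sits a 1.5-fold lower number from compound 1 to compound 3 (0.18 log units; within the scatter). Compound 2 `C[S+]([O-])/C=C/c1cc(=O)c2cc(C#N)ccc2o1` reaches only the limit of this assay, > 10000 nM, which is a limit rather than a number (the limit of > 10000 nM in this assay, at which 1 of the 3 values shown sits). From compound 1 to compound 2 the change is an at least 1.6-fold higher number from compound 1 to compound 2 (0.20 log units; that floor lies within the scatter), and from compound 2 to compound 3 it is an at least 2.4-fold lower number from compound 2 to compound 3 (0.38 log units; beyond the scatter).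

Compound 4 `CC(C)Oc1ccc2oc(/C=C/[S+](C)[O-])cc(=O)c2c1` differs from compound 3 by isopropyl in place of isopentyl on an oxygen on an aromatic ring. Within the data shown here, the only measured step that bears on this is the chain change between compound 1 and compound 3, a 1.5-fold lower number from compound 1 to compound 3 (0.18 log units; within the scatter), which lengthened the chain and moved the number within the scatter. Compound 4 shortens the chain again, part of the way back toward compound 1. No change beyond the scatter is therefore expected in this assay, the number of compound 4 being expected a little above that of compound 3, a 1.2-fold higher number from compound 3 to compound 4 (0.09 log units; within the scatter). Compound 4 is estimated at 5000 nM, within 2500 nM to 10000 nM.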

Compound 4, half-maximal inhibitory concentration: 8000 nM
Compound 4: the middle estimate sits 1.6-fold (0.20 log units) below what was measured; the range from low to high includes it.
By their numbers in this assay, from the lowest: compounds 3, 1 and 4 (each within the scatter of the next). At a limit, above all of these: compound 2.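

Replacing isopentyl with isopropyl on the oxygen on the aromatic ring stays within the scatter in this assay (a 2.0-fold higher number from compound 3 to compound 4 (0.29 log units; within the scatter)), and so does replacing propyl with isopropyl at the same place (a 1.3-fold higher number from compound 1 to compound 4 (0.11 log units; within the scatter)), so the branched isopropoxy group separates from neither of the other two ethers shown. What changes is the contrast with the nitrile: compound 3 stood clear of compound 2 (an at least 2.4-fold lower number from compound 2 to compound 3 (0.38 log units; beyond the scatter)), but the floor for compound 4 does not (an at least 1.2-fold lower number from compound 2 to compound 4 (0.09 log units; that floor lies within the scatter)), so isopropoxy cannot be told apart from cyano here, and only isopentyloxy among the ethers shown is separated from it. The compounds shown give no cause for any of these steps.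

On these data alone, whether any ether at this place moves the number beyond the scatter remains open, since propoxy, isopropoxy and isopentyloxy do not separate from one another. A longer chain such as octyloxy, or a chain ending in an amine or a carboxylic acid, would test whether this aromatic carbon tolerates more than small alkyl ethers.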